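This account rests on a few compounds, and the source may have more. Where it says the series, first, only, none or still open, it means among the compounds named here.

Compound 1 `Fc1cccc(-c2nc(Nc3ccccc3)c3cc(F)ccc3n2)c1`: 48300 nM in a functional assay on HT29-AK cells (Homo sapiens) for cytotoxicity, read by MTT assay, with a stated time of 48 h; a lower number here means a stronger inhibitor, a higher number a weaker inhibitor.
Compound 2 `Fc1cccc(-c2nc(Nc3ccccc3Cl)c3cc(F)ccc3n2)c1`: in this assay only a limit, > 50000 nM.

Compound 2 therefore stands at the weak end of what this assay can report, its number known only as the limit of > 50000 nM in this assay, at which 1 of the 2 values shown sits. Within the data shown here, the single measured step, an at least 1.0-fold higher number from compound 1 to compound 2 (0.01 log units; that floor lies within the scatter), came from chloro in place of hydrogen on an aromatic carbon and stayed within the scatter. Compound 3 `Cc1ccccc1Nc1nc(-c2cccc(F)c2)nc2ccc(F)cc12` differs from compound 2 by methyl in place of chloro on an aromatic carbon. Among the measured compounds shown here, since the one comparable change did not move the number beyond the scatter, no step beyond the scatter is expected here either. Compound 3 is thus expected to give about 50000 nM, between 20000 nM and 150000 nM, which means an expected step of a number no higher from compound 2 to compound 3 (the limit leaves the size open).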

Compound 3, half-maximal inhibitory concentration: > 50000 nM
Compound 3 gave a limit, no number; the forecaster's own chance of this, stated with the estimate: 60%; the middle value lies on the limit itself.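

Methyl on this aromatic carbon, ortho to a large group, gives an at least 1.0-fold higher number from compound 1 to compound 3 (0.01 log units; that floor lies within the scatter), so a second small group, this one of carbon rather than chlorine, also brings no measurable gain in this assay. The step between compound 2 and compound 3 cannot be read, and both compounds now end at the same limit: the limit of > 50000 nM in this assay, at which 2 of the 3 values shown sit.

From the compounds shown here alone, how far past that limit compound 2 and compound 3 lie stays open. So does whether another group at this place, such as an amine or a carboxylic acid, would bring the number into the readable range.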